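Swapping 4-nitrophenyl for 3-bromophenyl: a small step expected

The source may hold more compounds than are shown below. What is called first, only, known or untested is meant among the compounds shown, and "the series" means these compounds.

Among the compounds with values here, in a functional assay on A549 cells (Homo sapiens) for cytotoxicity, read by MTT assay, with a stated time of 24 h (on this read-out lower numbers stand for stronger inhibition and higher numbers for weaker inhibition), compound 1 (`COc1cc(/C=C(\C#N)C(=O)N/N=C(\C)c2c(O)c3ccc(O)cc3oc2=O)ccc1O`) gives 12600 nM and compound 2 (`C/C(=N\NC(=O)/C(C#N)=C/c1ccc([N+](=O)[O-])cc1)c1c(O)c2ccc(O)cc2oc1=O`) gives 9640 nM as the only measurements so far. Within the data shown here, compound 2 therefore cannot be ranked apart from compound 1, the one neighbour it can be compared with.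

Compound 3 (`C/C(=N\NC(=O)/C(C#N)=C/c1cccc(Br)c1)c1c(O)c2ccc(O)cc2oc1=O`) keeps the shared core and changes one group: 3-bromophenyl in place of 4-nitrophenyl on a double-bonded chain carbon bound to a double-bonded chain carbon.

One measured change bears on this, made at the same place. Putting 4-nitrophenyl in place of 4-hydroxy-3-methoxyphenyl gave a 1.3-fold lower number from compound 1 to compound 2 (0.12 log units; within the scatter) and so left the number within normal repeat variation. Among the measured compounds shown here, that is thin evidence, and no compound carrying bromine has been measured. Even so, the one exchange tested at this place suggests that no step beyond the scatter should be expected in this assay in either direction. The expected change is a 1.0-fold higher number from compound 2 to compound 3 (0.02 log units; within the scatter) and is therefore close to nothing. For compound 3 the estimated value is 10000 nM with an expected range from 4500 nM to 22000 nM in this read-out.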

Compound 3, half-maximal inhibitory concentration: 22200 nM
For compound 3 the middle estimate is 2.2-fold (0.35 log units) below the measured one; the measured number lies above the stated range.
By their numbers in this assay, from the lowest: compounds 2, 1 and 3 (each within the scatter of the next, the first and the last beyond it).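

In this assay, within the data shown here, this position now shows that it can move the number: putting 3-bromophenyl in place of 4-nitrophenyl gives a 2.3-fold higher number from compound 2 to compound 3 (0.36 log units; beyond the scatter) and is the first step at this place to clear the usual scatter, though only modestly. The same group in place of 4-hydroxy-3-methoxyphenyl gives a 1.8-fold higher number from compound 1 to compound 3 (0.25 log units; within the scatter) and stays within the scatter, so compound 1 cannot be separated from compound 2 or from compound 3, and the effect of bringing in 3-bromophenyl depends on which group it replaces. No measured property of these groups is available to account for the step.

The compounds shown leave open whether the step follows the bromine itself, its place on the phenyl ring, or the departure of the nitro group, which alone among these two groups carries hydrogen-bond acceptors. A 4-bromophenyl group would test the bromine at the place the nitro group held, and a plain phenyl or a 3-aminophenyl group would show how far the number depends on bromine at all.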